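The compounds below may be only part of what the source reports. "The series", "measured", "known", "first", "only" and "open" are said of these compounds alone.

Measured compounds:
- compound 1 `C=CC1=C(C(=O)NC(C)(C)C)C(c2ccc(OC)cc2)OC1`: > 100000 nM
- compound 2 `C=CC1=C(C(=O)NCCCCC)C(c2ccc(F)cc2)OC1`: > 100000 nM

In a functional assay on QGY7701 cells (Homo sapiens) for cytotoxicity, read by MTT assay, with a stated time of 24 h (a lower number here means a stronger inhibitor, a higher number a weaker inhibitor), compound 1 gives > 100000 nM, which is a limit of the assay and not a number. In this assay compound 2 likewise gives > 100000 nM, again a limit rather than a measured value. Among the measured compounds shown here, compound 1 therefore stands at the limit, and the limit of > 100000 nM in this assay, at which 2 of the 2 values shown sit, shows that no value so far lies anywhere else; there is no numerical range against which compound 1 could be ranked, and nothing is known about the tert-butyl amide beyond the fact that no inhibition was registered up to the limit.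

Compound 3 `C=CC1=C(C(=O)Nc2ccccc2)C(c2ccc(OC)cc2)OC1` is the next compound and is not yet measured in this assay. It differs from compound 1 in one place: phenyl in place of tert-butyl on an amide-type nitrogen.

For the measured compounds named here, with no measured step to lean on, the step from compound 1 to compound 3 is expected to be a step that the limit leaves unreadable from compound 1 to compound 3, that is, none beyond the scatter, and compound 3 is expected most probably to remain at the limit. The estimate for compound 3 in this assay is 150000 nM, with a range from 30000 nM to 600000 nM.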

Compound 3, half-maximal inhibitory concentration: > 100000 nM
Compound 3: no number, only a limit (the forecaster's own chance of this, stated with the estimate: 80%); the middle value does not contradict the limit.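

No step can be read between compound 1 and compound 3 in this assay, since each gives a limit and not a number. All compounds shown stand at the same place: the limit of > 100000 nM in this assay, at which 3 of the 3 values shown sit.

The compounds shown leave open whether any amide on this core reaches a measurable value in this assay, and how the amide groups would rank there.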